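Working notes on a two-compound series and a third analogue

The source may hold more compounds than are shown below. What is called first, only, known or untested is meant among the compounds shown, and "the series" means these compounds.

Measured so far:
compound 1 `CC(C)(C)c1nc2c(OCc3ccccc3)cccn2c1N` gives 2%
compound 2 `Cc1nc2c(OCc3ccccc3)cccn2c1CN` gives 49%

In a functional assay on the whole organism with Canis familiaris (Canis lupus familiaris) as the target, at a dose of 5 mg/kg by the intravenous route (a lower number here means a weaker effect, a higher number a stronger effect of the compound at the dose given), compound 2 gives 49%, the higher of the two numbers; compound 1 gives 2%, a gap beyond the usual scatter. Compound 3 `CCNc1c(C)nc2c(OCc3ccccc3)cccn12` differs from compound 2 in one place: ethylamino in place of aminomethyl on an aromatic carbon. Going by the values given here, no measured pair shows this change, so its size is not fixed by the data. A downward step is expected in this assay, of moderate size, beyond the scatter, given how far apart compound 1 and compound 2 stand. The expected step of a number 21 percentage points lower from compound 2 to compound 3 (beyond the scatter) points to a weaker effect. Compound 3 is estimated at 28%, within 5% to 55%.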

Compound 3, a percentage reported as inhibition, in the whole organism at one dose (the size of the read-out at that dose, not a potency): 70%
The estimate for compound 3 lay 42 percentage points below the measured number; measured number above the stated range.
By their numbers in this assay, from the lowest: compound 1; then compound 2; then compound 3.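

In this assay, ethylamino in place of aminomethyl on this aromatic carbon gives a number 21 percentage points higher from compound 2 to compound 3 (beyond the scatter), so this position tolerates the swap and the effect at the dose given rises. The swap adds one heavy atom and leaves the counts of hydrogen-bond donors and acceptors and the net charge unchanged. No measurement at hand accounts for the step.

From the compounds shown here alone, whether a longer chain such as propylamino or a carboxylic acid on this carbon would keep the effect remains open. Potency also remains open, since the read-out reflects a single dose.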